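The compounds below may be only part of what the source reports. "The series", "measured", "known", "first", "only" and "open" are said of these compounds alone.

In an ADME assay on HepG2 cells (Homo sapiens) for cytotoxicity, read by MTT assay, with a stated time of 72 h (a higher number here means that more compound is tolerated, a lower number that less compound is tolerated), compound 1 (`CC1(c2ccc(-c3ccccc3C#N)cc2)CC(S(=O)(=O)c2ccc(F)cc2)=C(c2ccc(/C(N)=N\O)cc2)O1`) gives 58300 nM and compound 2 (`CC1(Cc2ccccc2)CC(S(=O)(=O)c2ccccc2F)=C(c2ccc(/C(N)=N\O)cc2)O1`) gives 61700 nM. For the measured compounds named here, these two values lie within the scatter of each other, so compound 1 stands level with the only other measured compound. Going by the values given here, the two structures differ in more than one place, and no measured pair isolates a single change, so the data hold no direct precedent for the next step.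

Compound 3 (`CC1(c2ccc(Cl)cc2)CC(S(=O)(=O)c2ccc(F)cc2)=C(c2ccc(/C(N)=N\O)cc2)O1`) is still to be measured. Its change from compound 1 is chloro in place of 2-cyanophenyl on an aromatic carbon, para to a large group: chloro in place of 2-cyanophenyl on an aromatic carbon.

No step beyond the scatter is expected in this assay, in either direction. This expectation rests only on compound 1 at 58300 nM and compound 2 at 61700 nM, which is thin support, so the range is kept wide. The expected change is a 1.1-fold lower number from compound 1 to compound 3 (0.03 log units; within the scatter). For compound 3 the estimated value is 55000 nM, with an expected range of 27000 nM to 110000 nM.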

Compound 3, half-maximal cytotoxic concentration: 61400 nM
Estimate against measurement, compound 3: 1.1-fold (0.05 log units) below; the range from low to high includes it.
By their numbers in this assay, from the lowest: compounds 1, 3 and 2 (each within the scatter of the next).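

In this assay, chloro in place of 2-cyanophenyl on an aromatic carbon, para to a large group, gives a 1.1-fold higher number from compound 1 to compound 3 (0.02 log units; within the scatter). For the compounds shown here, this is the first comparison that isolates one place, and it shows compound 1 and compound 3 level at this position, although 2-cyanophenyl brings a six-membered aromatic ring and a nitrile while chloro is a single chlorine atom. For tolerance in this cell assay, the result therefore gives no sign that the choice between these two groups matters, and no measurement shown here accounts for that outcome.

The compounds shown leave open whether an amine, a carboxylic acid or a longer alkyl chain at the same place would also stand level with compound 1 and compound 3, as only 2-cyanophenyl and chloro appear there in this comparison. Going by these compounds alone, they also leave open whether the same reading would hold with the fluorine elsewhere on the phenylsulfonyl group, and compound 2 differs from compound 1 and compound 3 in more than one place, so it offers no step on this question.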